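The source may hold more compounds than are shown below. What is called first, only, known or untested is meant among the compounds shown, and "the series" means these compounds.

In a functional assay on PC-6 cells (Homo sapiens) for cytotoxicity, read by MTT assay, with a stated time of 3 days (on this read-out higher numbers stand for weaker inhibition and lower numbers for stronger inhibition), compound 2 `CNCc1ccc(/C=N/Nc2ncnc3sc(C(C)(C)C)cc23)cc1` gives 0.044 ug/mL. For the measured compounds named here, compound 3 `CC(C)(C)c1cc2c(N/N=C/c3ccc4c(c3)CNC4)ncnc2s1` gives 0.071 ug/mL, level with compound 2 within the scatter, so these two share the low end of the numbers so far. Compound 1 `CN(C)Cc1ccc(/C=N/Nc2ncnc3sc(C(C)(C)C)cc23)cc1` gives 0.107 ug/mL. Compound 4 `CC(C)(C)c1cc2c(N/N=C/c3ccccc3)ncnc2s1` has hydrogen in place of (methylamino)methyl on an aromatic carbon. Going by the values given here, the only measured step, a 2.4-fold lower number from compound 1 to compound 2 (0.39 log units; beyond the scatter), is modest and concerns just a methyl on the amine nitrogen, so it guides this larger change only loosely. Among the compounds with values here, no measured compound lacks the amine nitrogen, so the direction is uncertain, though a rise beyond the scatter is expected. The estimated step is a 5.7-fold higher number from compound 2 to compound 4 (0.75 log units; beyond the scatter). Compound 4 is expected near 0.25 ug/mL, with an estimated range of 0.05 ug/mL to 1.2 ug/mL.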

Compound 4, half-maximal inhibitory concentration: 6.54 ug/mL
Compound 4: the middle estimate sits 26-fold (1.42 log units) below what was measured; measured number outside the range, above it.
By their numbers in this assay, from the lowest: compounds 2, 3 and 1 (each within the scatter of the next, the first and the last beyond it); then compound 4.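

Taking the side chain off this aromatic carbon matters far more than trimming the amine on it: this assay shows a 150-fold higher number from compound 2 to compound 4 (2.17 log units; beyond the scatter) and a 61-fold higher number from compound 1 to compound 4 (1.79 log units; beyond the scatter) when hydrogen replaces (methylamino)methyl or (dimethylamino)methyl. Among these compounds, then, keeping an amine-bearing group at this place goes with the low numbers, and the exact substitution on its nitrogen counts for much less. Nothing available explains why. Still open, on these data alone, is whether the nitrogen itself counts, or merely the added carbon. A plain methyl, a hydroxymethyl or a carboxylic acid on this carbon would separate the two.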